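A Urea Replaces the Benzyl Group on a Weak Series

This account rests on a few compounds, and the source may have more. Where it says the series, first, only, none or still open, it means among the compounds named here.

Compound 1 `NC(=O)c1c(NC(=O)c2ccccc2Cl)sc2c1CCN(Cc1ccccc1)C2` gives 38400 nM in a functional assay on HeLa cells (Homo sapiens) for antiproliferative activity, with a stated time of 24 h; on this read-out higher numbers stand for weaker inhibition and lower numbers for stronger inhibition.
Compound 2 `NC(=O)c1c(NC(=O)c2ccccc2Cl)sc2c1CCN(Cc1ccc(Cl)cc1)C2` gives only a limit of the assay, > 50000 nM.
Compound 3 `NC(=O)c1c(NC(=O)c2ccccc2Cl)sc2c1CCN(Cc1ccc([N+](=O)[O-])cc1)C2` gives 46100 nM.

Compound 3 holds the highest of the two numbers shown; its nearest neighbour is compound 1, with a 1.2-fold higher number from compound 1 to compound 3 (0.08 log units; within the scatter). Compound 2 sits at the limit of > 50000 nM in this assay, at which 1 of the 3 values shown sits.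

Compound 4 `NC(=O)c1c(NC(=O)c2ccccc2Cl)sc2c1CCN(C(=O)Nc1ccccc1Cl)C2` differs from compound 3 by (2-chlorophenyl)carbamoyl in place of 4-nitrobenzyl on an amine nitrogen in a ring. The measured steps, an at least 1.3-fold higher number from compound 1 to compound 2 (0.11 log units; that floor lies within the scatter) and an at least 1.0-fold lower number from compound 2 to compound 3 (0.03 log units; that floor lies within the scatter), only vary a substituent on the benzyl ring and never exchange the benzyl group itself, so they bear on this change only loosely; what they do show is that the numbers hardly move. The step to compound 4 is therefore expected to stay within the scatter, a 1.0-fold lower number from compound 3 to compound 4 (0.01 log units; within the scatter). Compound 4 is estimated at 45000 nM, between 15000 nM and 150000 nM.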

Compound 4, half-maximal inhibitory concentration: 45400 nM
Beside the measured number, compound 4's estimate is 1.0-fold (0.00 log units) below it; measured number inside the range.
By their numbers in this assay, from the lowest: compounds 1, 4 and 3 (each within the scatter of the next). At a limit, above all of these: compound 2.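

Exchanging the whole benzyl group for (2-chlorophenyl)carbamoyl on the ring amine nitrogen, not just a substituent on its ring, leaves the number unmoved: a 1.0-fold lower number from compound 3 to compound 4 (0.01 log units; within the scatter), and a 1.2-fold higher number from compound 1 to compound 4 (0.07 log units; within the scatter). Compound 2 gives only a limit of the assay, so this comparison is merely a floor: an at least 1.1-fold lower number from compound 2 to compound 4 (0.04 log units; that floor lies within the scatter). Nothing shown explains why the number stays flat.

All of these groups carry a six-membered aromatic ring of carbon only. As far as these compounds go, whether a simple alkyl chain, a carboxylic acid or a free amine at this nitrogen would shift the number remains open.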